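Adding a chlorine to a thiazole core: solubility

The compounds below may be only part of what the source reports. "The series", "measured", "known", "first", "only" and "open" are said of these compounds alone.

Compound 1 `CCOc1ccc(-c2csc(Nc3ccc(Cl)cn3)n2)nc1` and compound 2 `CCOc1ccc(-c2nc(Nc3ccc(Cl)cn3)sc2Cl)nc1` share one core, and compound 3 `Clc1ccc(Nc2nc(-c3cccnn3)cs2)nc1` and the unmeasured compound 4 `Clc1ccc(Nc2nc(-c3cccnn3)c(Cl)s2)nc1` share another; how the two cores differ is not broken down here. In a physicochemical assay for solubility, in phosphate buffer, with a stated time of 2 h, at pH 7.4 (on this read-out lower numbers stand for lower solubility and higher numbers for higher solubility), compound 1 gives only a limit, < 10000 nM. In this assay compound 2 likewise gives only a limit, < 10000 nM. In this assay compound 3 gives 20000 nM. The change from compound 1 to compound 2 is chloro in place of hydrogen on an aromatic carbon, and its step is a step that the two limits leave unreadable from compound 1 to compound 2, since the limit of < 10000 nM in this assay, at which 2 of the 3 values shown sit, marks where both sit. The change from compound 3 to compound 4 is the same kind of change, (chloro in place of hydrogen on an aromatic carbon), though here the chloro sits next to the ring atom that bears a pyridazin-3-yl group (6 heavy atoms) rather than a group of 9 heavy atoms. For compound 4 a step of a 2.0-fold lower number from compound 3 to compound 4 (0.30 log units; within the scatter) is expected, resting on compound 3 at 20000 nM and on the unreadable step that the two limits leave unreadable from compound 1 to compound 2. Compound 4 is estimated at 10000 nM.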

Compound 4, solubility: < 10000 nM
Compound 4: no number, only a limit; the forecaster's own chance of this, stated with the estimate: 50%; the middle value lies on the limit itself.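

As far as these compounds go, on the core of compound 3, putting chloro in place of hydrogen gives in this assay an at least 2.0-fold lower number from compound 3 to compound 4 (0.30 log units; that floor lies within the scatter), and this is only a floor, so the true size of the step stays unknown. The matching step on the core of compound 1 cannot be read, so the data show no size that carries from one core to the other, and they neither confirm nor rule out a shared effect of the change. Most of the results stop at the same point: the limit of < 10000 nM in this assay, at which 3 of the 4 values shown sit.

The compounds shown leave open how other groups on this ring carbon, such as an amine or a carboxylic acid, would read on either core. They also leave open whether such a group would give a number rather than a limit.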